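A few compounds are considered here, and "the series" means these few. Any claim that something is new, unique, unknown or untested is made for them only; others in the source may bear on it.

Measured so far in a physicochemical assay for solubility, with a stated time of 18 h, at pH 7.4; a lower number here means a less soluble compound, a higher number a more soluble compound:
- compound 1 `COc1ccc(F)cc1CNCCCNc1ccnc2cc(CCc3ccccc3)ccc12`: 4200 nM
- compound 2 `Cc1cc(C)cc(Cc2ccc3c(NCCCNCc4ccco4)ccnc3c2)c1`: 4200 nM
- compound 3 `c1ccc(CCc2ccc3c(NCCCNCc4ccco4)ccnc3c2)cc1`: 4200 nM

Compound 1 stands level with compounds 2 and 3; all three sit at the same figure, with no ordering among them. The two steps that join them, no change at the digits printed from compound 1 to compound 3 (within the scatter) and no change at the digits printed from compound 2 to compound 3 (within the scatter), were both flat within the scatter, although each altered a different end of the shared core.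

Compound 4 `COc1ccc(F)cc1CNCCCNc1ccnc2cc(Oc3cccc(N(C)C)c3)ccc12` is the next to be measured. It differs from compound 1 as follows: 3-(dimethylamino)phenoxy in place of phenethyl on an aromatic carbon. For the measured compounds named here, no measured step exchanges a group at this aromatic carbon, so neither of the two flat steps bears on it directly; they only show that the series has so far not moved. On that basis the step of no change at the digits printed from compound 1 to compound 4 (within the scatter) is expected to stay within the scatter. Compound 4 is therefore estimated at 4200 nM, with a range from 1800 nM to 9000 nM.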

Compound 4, solubility: 14500 nM
Estimate against measurement, compound 4: 3.5-fold (0.54 log units) below, outside the stated range (above it).
By their numbers in this assay, from the lowest: compounds 1, 2 and 3 (each within the scatter of the next); then compound 4.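

In this assay, for the compounds shown here, 3-(dimethylamino)phenoxy in place of phenethyl on this aromatic carbon gives a 3.5-fold higher number from compound 1 to compound 4 (0.54 log units; beyond the scatter), the first step beyond the scatter. The series can therefore move at this position, with the entering group carrying 2 hydrogen-bond acceptors where phenethyl carried 0. No measurement on hand bears on the reason for the rise.

The change replaces the link and the ring substitution together, so their shares remain unseparated. Plain phenoxy, or phenethyl bearing a dimethylamino group, would divide them.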